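The compounds below may be only part of what the source reports. "The series", "measured", "known", "first", "only" and "open" are said of these compounds alone.

Compound 3 `CCN(CC)S(=O)(=O)c1ccc(S(=O)(=O)N2CCC[C@@H](C(=O)N3CCC(F)(F)CC3)C2)cc1` carries a 4,4-difluoropiperidin-1-yl group on its carbonyl carbon and gives the lowest number of the three measured in a functional assay on MIA PaCa-2 cells (Homo sapiens) for inhibition, read by MTT assay, with a stated time of 3 days (a lower number here means a stronger inhibitor, a higher number a weaker inhibitor), with 19 nM. Compound 1 `CCN(CC)S(=O)(=O)c1ccc(S(=O)(=O)N2CCC[C@@H](C(=O)N3CCC(O)CC3)C2)cc1` gives 230 nM, and compound 2 `CCN(CC)S(=O)(=O)c1ccc(S(=O)(=O)N2CCC[C@@H](C(=O)N3CCC(C(F)(F)F)CC3)C2)cc1` gives 110 nM. Compound 4 `CCN(CC)S(=O)(=O)c1ccc(S(=O)(=O)N2CCC[C@@H](C(=O)N3CCS(=O)(=O)CC3)C2)cc1` differs from compound 3 by 1,1-dioxothiomorpholin-4-yl in place of 4,4-difluoropiperidin-1-yl on a carbonyl carbon. The measured steps that bear on this are a 12-fold lower number from compound 1 to compound 3 (1.08 log units; beyond the scatter) and a 5.8-fold lower number from compound 2 to compound 3 (0.76 log units; beyond the scatter): both other groups tried at this carbonyl carbon gave higher numbers than compound 3 in this assay. Because compound 1 with its hydroxy group sits at 230 nM, a return toward higher numbers is expected, with an expected step of a 7.9-fold higher number from compound 3 to compound 4 (0.90 log units; beyond the scatter). Compound 4 is therefore estimated at 150 nM, within a range from 40 nM to 600 nM.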

Compound 4, half-maximal inhibitory concentration: 220 nM
Compound 4: middle estimate off by 1.5-fold (0.17 log units), on the low side; measured number inside the range.
By their numbers in this assay, from the lowest: compound 3; then compounds 2, 4 and 1 (each within the scatter of the next, the first and the last beyond it).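

In this assay, swapping the 4,4-difluoropiperidin-1-yl group for 1,1-dioxothiomorpholin-4-yl, another six-membered ring, gives a 12-fold higher number from compound 3 to compound 4 (1.06 log units; beyond the scatter) and does not keep the low number of compound 3. Compound 4 cannot be told apart from the other two compounds, as a 2.0-fold higher number from compound 2 to compound 4 (0.30 log units; within the scatter) and a 1.0-fold lower number from compound 1 to compound 4 (0.02 log units; within the scatter) both lie within the scatter, so among these four only compound 3 stands clear of compound 1 and compound 4. Nothing shown here explains this gap. Going by these compounds, whether a 4-fluoropiperidin-1-yl or a morpholin-4-yl group on this carbonyl carbon would stay near compound 3 remains open.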